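The source may hold more compounds than are shown below. What is called first, only, known or untested is meant among the compounds shown, and "the series" means these compounds.

The three measured compounds share one core and differ only in the aryl group attached to a carbonyl carbon. Compound 1 `Cc1nc(C)c(/C=C/C(=O)c2ccc(NC(=O)c3ccccc3F)cc2)nc1C` gives 1270 nM in a functional assay on MCF7 cells (Homo sapiens) for antiproliferative activity, read by CCK-8 assay, with a stated time of 72 h; on this read-out lower numbers stand for stronger inhibition and higher numbers for weaker inhibition. Compound 2 `COc1ccc(C(=O)Nc2ccc(C(=O)/C=C/c3nc(C)c(C)nc3C)cc2)cc1OC` gives 1660 nM. Compound 3 `Cc1ccc(C(=O)Nc2ccc(C(=O)/C=C/c3nc(C)c(C)nc3C)cc2)cc1` gives 1180 nM. Compound 3 carries the smallest of the three numbers, yet the steps of a 1.1-fold lower number from compound 1 to compound 3 (0.03 log units; within the scatter) and a 1.4-fold lower number from compound 2 to compound 3 (0.15 log units; within the scatter) both lie within the scatter, so the three compounds cannot be told apart on these numbers. Compound 4 `COc1ccc(C(=O)Nc2ccc(C(=O)/C=C/c3nc(C)c(C)nc3C)cc2)cc1` differs from compound 3 by methoxy in place of methyl on an aromatic carbon. All three measured steps bear on this change, each exchanging one aryl group for another on the same carbonyl carbon, and each of them stays within the scatter: a 1.3-fold higher number from compound 1 to compound 2 (0.12 log units; within the scatter), a 1.1-fold lower number from compound 1 to compound 3 (0.03 log units; within the scatter) and a 1.4-fold lower number from compound 2 to compound 3 (0.15 log units; within the scatter). A step of no larger size, in no particular direction, is therefore expected for compound 4 in this assay, the expected step being a 1.0-fold higher number from compound 3 to compound 4 (0.01 log units; within the scatter). Compound 4 is estimated at 1200 nM, within a range from 600 nM to 2400 nM.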

Compound 4, half-maximal inhibitory concentration: 1410 nM
The estimate for compound 4 lay 1.2-fold (0.07 log units) below the measured number; the measured number falls inside the stated range.
By their numbers in this assay, from the lowest: compounds 3, 1, 4 and 2 (each within the scatter of the next).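

In this assay, for the compounds shown here, methoxy in place of methyl on an aromatic carbon, para to a large group, gives a 1.2-fold higher number from compound 3 to compound 4 (0.08 log units; within the scatter), the first measured change confined to a single substituent at this position rather than an exchange of the whole aryl group. Hydrogen in place of methoxy on an aromatic carbon of the same ring gives a 1.2-fold lower number from compound 2 to compound 4 (0.07 log units; within the scatter), and 4-methoxyphenyl in place of 2-fluorophenyl gives a 1.1-fold higher number from compound 1 to compound 4 (0.05 log units; within the scatter). All three steps stay within the scatter, so the added oxygen and hydrogen-bond acceptor of the methoxy group leave no readable mark on the number in this series.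

No measurement shown here offers an explanation for this flat result. Going by these compounds, whether an amine, a carboxylic acid or a longer alkoxy chain at this position would also stay within the scatter remains open.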